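The source may report more compounds than this note shows. Statements on the series, on what has been measured and on what is new or still open speak of the compounds shown alone.

Compound 1, `CC(C)c1ccc(NC(=O)[C@H]2CN(C)C[C@@H]2c2ccc(/C=C/C(=O)Nc3ccccc3N)cc2)cc1`: 54 mL/min/kg in an in vitro ADME assay on microsomes from liver (Mus musculus) for pharmacokinetics, read by LC-MS, with a stated time of 10 min, tested at 1 uM; a lower number here means slower removal, a higher number faster removal of the compound
Compound 2, `CN1C[C@H](C(=O)Nc2ccc(C(F)(F)F)cc2)[C@@H](c2ccc(/C=C/C(=O)Nc3ccccc3N)cc2)C1`: 23 mL/min/kg in this assay

Compound 1 stands highest of the two numbers shown, with compound 2 the only neighbour, reached by a 2.3-fold lower number from compound 1 to compound 2 (0.37 log units; beyond the scatter); that step was a change of trifluoromethyl in place of isopropyl on an aromatic carbon. Compound 3, `CN1C[C@H](C(=O)Nc2ccc(F)c(F)c2)[C@@H](c2ccc(/C=C/C(=O)Nc3ccccc3N)cc2)C1`, has not yet been measured in this assay. It differs from compound 1 by 3,4-difluorophenyl in place of 4-isopropylphenyl on an amide-type nitrogen. The measured step from compound 1 to compound 2 bears on this, since there too the isopropyl group was removed from the same ring of the shared core, and it gave a modest fall beyond the scatter. A fall of a broadly similar size is therefore expected here, though the two fluorines are not the same group as trifluoromethyl, so the size is uncertain. Compound 3 is expected to give about 27 mL/min/kg in this assay, between 13 mL/min/kg and 55 mL/min/kg, which would mean an estimated 2.0-fold lower number from compound 1 to compound 3 (0.30 log units; within the scatter).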

Compound 3, clearance: 46 mL/min/kg
The estimate for compound 3 lay 1.7-fold (0.23 log units) below the measured number; measured number inside the range.
By their numbers in this assay, from the lowest: compounds 2, 3 and 1 (each within the scatter of the next, the first and the last beyond it).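

On this amide-type nitrogen, the change to 3,4-difluorophenyl gives a 1.2-fold lower number from compound 1 to compound 3 (0.07 log units; within the scatter) in this assay and so cannot be told apart from no change. Compound 3 also sits close to the trifluoromethyl compound, with a 2.0-fold higher number from compound 2 to compound 3 (0.30 log units; within the scatter) on that side, even though a 2.3-fold lower number from compound 1 to compound 2 (0.37 log units; beyond the scatter) is a step beyond the scatter; the three numbers therefore do not divide into two clear groups, and one fluorine-bearing ring does not settle how another will behave. Nothing measured here explains these numbers.

The compounds shown leave open how 4-fluorophenyl would compare, which would help separate the contributions of the two fluorines. They also leave open how a phenyl ring carrying an amine or a carboxylic acid, or a longer chain in place of the ring, would read at this nitrogen.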